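A few compounds are considered here, and "the series" means these few. Any claim that something is new, unique, unknown or untested is made for them only; others in the source may bear on it.

In a functional assay on RL cells (Homo sapiens) for cytotoxicity, with a stated time of 48 h (a lower number here means a stronger inhibitor, a higher number a weaker inhibitor), compound 1 `COc1cc(O)c(C(=O)/C=C/c2ccc(F)cc2)c(OC)c1` gives 5400 nM while compound 2 `COc1cccc(/C=C/C(=O)c2c(OC)cc(OC)cc2OC)c1` gives 5900 nM and compound 3 `COc1cc(O)c(C(=O)/C=C/c2ccccc2OC)c(OC)c1` gives 10100 nM in the same test. Compound 2 therefore sits within the usual scatter of both other compounds. Compound 4 `COc1cc(OC)c(C(=O)/C=C/c2ccc(Cl)cc2)c(OC)c1` carries 4-chlorophenyl in place of the 3-methoxyphenyl of compound 2 on a double-bonded chain carbon bound to a double-bonded chain carbon (4-chlorophenyl in place of 3-methoxyphenyl on a double-bonded chain carbon bound to a double-bonded chain carbon). Within the data shown here, no two measured compounds differ in only one place, so no measured step guides this change. The expectation in this assay is therefore no shift beyond the scatter in either direction. The expected step of a 1.3-fold lower number from compound 2 to compound 4 (0.12 log units; within the scatter) is an estimate that stays within that scatter. Compound 4 is estimated at 4500 nM with a likely range from 1800 nM to 11000 nM in this test.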

Compound 4, half-maximal inhibitory concentration: 6500 nM
Estimate against measurement, compound 4: 1.4-fold (0.16 log units) below, within the range that was stated.
By their numbers in this assay, from the lowest: compounds 1, 2, 4 and 3 (each within the scatter of the next).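

In this assay, among these compounds, exchanging 3-methoxyphenyl for 4-chlorophenyl on a double-bonded chain carbon bound to a double-bonded chain carbon gives a 1.1-fold higher number from compound 2 to compound 4 (0.04 log units; within the scatter), the first direct comparison at this position. Here, a ring carrying chlorine and no hydrogen-bond acceptor serves as well as one carrying a methoxy group. Nothing available explains this result. This single step cannot separate losing the methoxy group from gaining the chlorine. From the compounds shown here alone, whether an amine or a carboxylic acid on this ring would also leave the number unchanged remains open.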